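Swapping the Aryl Group on a Piperidine Sulfonamide

A few compounds are considered here, and "the series" means these few. Any claim that something is new, unique, unknown or untested is made for them only; others in the source may bear on it.

Compound 1 `CC1CCN(C2CCN(S(=O)(=O)c3ccc(C#N)cc3)CC2)CC1` is the starting point. In an ADME assay on HCT-116 cells (Homo sapiens) for cytotoxicity, read by CellTiter-Glo, with a stated time of 72 h (a higher number here means a weaker inhibitor, a lower number a stronger inhibitor), compound 1 gives > 5000 nM, which is a limit of the assay rather than a number. The same is true of compound 2 `CC1CCN(C2CCN(S(=O)(=O)c3ccc(-c4ccccc4)cc3)CC2)CC1`, whose value in this assay is > 5000 nM, again a limit. Compound 3 `CC1CCN(C2CCN(S(=O)(=O)c3ccc(C(C)C)cc3)CC2)CC1` also reaches only a limit in this assay, > 5000 nM. Because all three sit at the limit of > 5000 nM in this assay, at which 3 of the 3 values shown sit, the changes among them cannot be read: the step that the two limits leave unreadable from compound 1 to compound 2, the step that the two limits leave unreadable from compound 1 to compound 3 and the step that the two limits leave unreadable from compound 2 to compound 3 all lie behind the same limit, so the three measured compounds place compound 1 at the limit and nowhere more exact.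

Compound 4 `CC1CCN(C2CCN(S(=O)(=O)c3cncc(Br)c3)CC2)CC1` differs from compound 1 by 5-bromopyridin-3-yl in place of 4-cyanophenyl on a sulfonyl sulfur. Going by the values given here, no measured step bears on this change; the three steps known all sit behind the limit, and none of them gives a direction. The expected step that the limit leaves unreadable from compound 1 to compound 4 is therefore none beyond the scatter, with the value of compound 4 expected to stay near the limit. Compound 4 is estimated at 8000 nM in this assay, within a range from 2500 nM to 30000 nM.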

Compound 4, half-maximal inhibitory concentration: > 10000 nM
Compound 4: only a limit was reported (the forecaster's own chance of this, stated with the estimate: 80%); at least 1.2-fold (0.09 log units) between middle value and limit.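

Compound 4 gives > 10000 nM in this assay, which is a limit of the assay and not a number. Compound 1 also stands at a limit, so the change between compound 1 and compound 4 cannot be read. The compounds shown leave open whether any group on the sulfonyl sulfur brings a readable value.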